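From Methoxy to Ethoxy on Compound 1

The compounds below may be only part of what the source reports. "The series", "measured", "known", "first", "only" and "open" are said of these compounds alone.

In a functional assay on HeLa cells (Homo sapiens) for antiproliferative activity, read by CCK-8 assay, with a stated time of 72 h (a higher number here means a weaker inhibitor, a lower number a stronger inhibitor), compound 1 `COc1ccc(-c2cncnc2-c2cc(OC)c(OC)c(OC)c2)cc1Cl` gives 320 nM, compound 2 `COc1cc(-c2ncncc2-c2ccc(SC)cc2)cc(OC)c1OC` gives 220 nM and compound 3 `CCSc1ccc(-c2cncnc2-c2cc(OC)c(OC)c(OC)c2)cc1` gives 370 nM. Compound 1 stands level with both others, since its two steps are a 1.5-fold lower number from compound 1 to compound 2 (0.16 log units; within the scatter) and a 1.2-fold higher number from compound 1 to compound 3 (0.06 log units; within the scatter). Compound 4 `CCOc1ccc(-c2cncnc2-c2cc(OC)c(OC)c(OC)c2)cc1Cl` differs from compound 1 by methyl in place of hydrogen on a saturated chain carbon bound to an oxygen on an aromatic ring, so methoxy becomes ethoxy. The closest measured parallel adds methyl on a saturated chain carbon bound to a sulfur, and that step is a 1.7-fold higher number from compound 2 to compound 3 (0.23 log units; within the scatter). No change beyond the scatter is therefore expected in this assay, and the estimated step is a 1.2-fold higher number from compound 1 to compound 4 (0.07 log units; within the scatter). Compound 4 is estimated at 380 nM, within an expected range of 190 nM to 750 nM.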

Compound 4, half-maximal inhibitory concentration: 90 nM
For compound 4 the middle estimate is 4.2-fold (0.63 log units) above the measured one; measured number outside the range, below it.
By their numbers in this assay, from the lowest: compound 4; then compounds 2, 1 and 3 (each within the scatter of the next).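

In this assay, going by these compounds alone, ethoxy in place of methoxy is the one step here that lies beyond the scatter (a 3.6-fold lower number from compound 1 to compound 4 (0.55 log units; beyond the scatter)). A single added methyl at this place can therefore shift the number, which compounds 2 and 3 did not show for the sulfur-bound chain. The same addition also fails to carry over from one core to the other: the same change on two cores in this assay, a 1.7-fold higher number (0.23 log units; within the scatter) from compound 2 to compound 3 and a 3.6-fold lower number (0.55 log units; beyond the scatter) from compound 1 to compound 4, 6.0-fold (0.78 log units) apart, beyond the scatter of two such steps.

On these data alone, whether a longer chain such as propyl, or a chain ending in an amine, would lower the number further stays open. So does whether the step depends on the chloro group shared by compound 1 and compound 4.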